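The source may report more compounds than this note shows. Statements on the series, on what has been measured and on what is new or still open speak of the compounds shown alone.

Measured in a functional assay for inhibition, with Rattus norvegicus as the target; on this read-out higher numbers stand for weaker inhibition and lower numbers for stronger inhibition:

Compound 1 `CC(/N=c1\c(O)c(O)\c1=N/c1ccc(C#N)cc1)C(C)(C)C`: 520 nM
Compound 2 `CC(C)(C)/N=c1\c(O)c(O)\c1=N/c1ccc(C#N)cc1`: 560 nM
Compound 3 `C/N=c1\c(O)c(O)\c1=N/c1ccc(C#N)cc1`: > 30000 nM

For compound 3 the assay gives only a limit, > 30000 nM, and not a number. Compound 4 `C[C@@H](/N=c1\c(O)c(O)\c1=N/c1ccc(C#N)cc1)C1CCCCC1` differs from compound 3 at one place: 1-cyclohexylethyl in place of methyl on a double-bonded nitrogen. Among the measured compounds shown here, three measured steps bear on this change. Putting methyl in place of a larger group was costly both times: an at least 57-fold higher number from compound 1 to compound 3 (1.76 log units; beyond the scatter) and an at least 53-fold higher number from compound 2 to compound 3 (1.72 log units; beyond the scatter). Exchanging the two larger groups made no real difference: a 1.1-fold higher number from compound 1 to compound 2 (0.03 log units; within the scatter). Compound 4 again carries a larger group, so a large move toward stronger inhibition in this assay is expected: an at least 66-fold lower number from compound 3 to compound 4 (1.82 log units; beyond the scatter). The estimate for compound 4 is 450 nM, with an expected range of 100 nM to 2500 nM.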

Compound 4, half-maximal inhibitory concentration: 2600 nM
Compound 4: the middle estimate sits 5.8-fold (0.76 log units) below what was measured; the measured number lies above the stated range.
By their numbers in this assay, from the lowest: compounds 1 and 2 (each within the scatter of the next); then compound 4. At a limit, above all of these: compound 3.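

In this assay, 1-cyclohexylethyl on the double-bonded nitrogen recovers much of what methyl lacks: an at least 11-fold lower number from compound 3 to compound 4 (1.06 log units; beyond the scatter). Larger groups at this place are nevertheless not interchangeable, as compounds 1 and 2 alone might suggest: a 4.6-fold higher number from compound 2 to compound 4 (0.67 log units; beyond the scatter) and a 5.0-fold higher number from compound 1 to compound 4 (0.70 log units; beyond the scatter). The gain over compound 3 is a minimum and not an exact size, since compound 3 has only a limit: the limit of > 30000 nM in this assay, at which 1 of the 4 values shown sits.

Still open, going by these compounds, is whether a plain cyclohexyl or a phenyl group on this nitrogen would match tert-butyl. Also open, on these data alone, is how the mirror-image form of 1-cyclohexylethyl would compare.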